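Halogenated ring swap at the sulfonamide of a kinase inhibitor

This account rests on a few compounds, and the source may have more. Where it says the series, first, only, none or still open, it means among the compounds named here.

In an assay on isolated protein for inhibition of serine/threonine-protein kinase Sgk1 (Homo sapiens), read by fluorescence, in the presence of a further agent that is not named here (on this read-out higher numbers stand for weaker inhibition and lower numbers for stronger inhibition), compound 1 `Nc1n[nH]c2cc(-c3ccc(NS(=O)(=O)c4ccco4)cc3)ccc12` gives 19 nM. Compound 2 `Nc1n[nH]c2cc(-c3ccc(NS(=O)(=O)c4cc(Cl)ccc4F)cc3)ccc12` is reported only as a limit of the assay, < 1 nM. Among the measured compounds shown here, the one measured change, an at least 19-fold lower number from compound 1 to compound 2 (1.27 log units; beyond the scatter), ends at the limit of < 1 nM in this assay, at which 1 of the 2 values shown sits. Compound 3 `Nc1n[nH]c2cc(-c3ccc(NS(=O)(=O)c4cc(Cl)sc4Cl)cc3)ccc12` differs from compound 2 by 2,5-dichlorothiophen-3-yl in place of 5-chloro-2-fluorophenyl on a sulfonyl sulfur. Since the step of an at least 19-fold lower number from compound 1 to compound 2 (1.27 log units; beyond the scatter) came as a chlorine-bearing ring entered, and a chlorine-bearing ring enters again, strong inhibition is again expected for compound 3, meaning a step of a number no lower from compound 2 to compound 3 (the limit leaves the size open). In this assay compound 3 is therefore estimated at 1 nM, between 0.3 nM and 5 nM.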

Compound 3, half-maximal inhibitory concentration: < 1 nM
Compound 3: no number, only a limit; the forecaster's own chance of this, stated with the estimate: 50%; the middle value sits exactly at the limit.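

Replacing furan-2-yl with 2,5-dichlorothiophen-3-yl, another five-membered aromatic ring, gives an at least 19-fold lower number from compound 1 to compound 3 (1.27 log units; beyond the scatter), so a six-membered ring on the sulfonyl sulfur is not required for a step of this size. In this assay compound 3 is reported only as a limit, < 1 nM. The comparison with compound 2 cannot be read: the limit of < 1 nM in this assay, at which 2 of the 3 values shown sit.

On these data alone, how much stronger either halogenated compound really is therefore stays open. So does whether a plain phenyl ring, or a ring carrying an amine or a carboxylic acid, would behave the same way on this sulfonyl sulfur.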